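From pyridin-3-yl to pyridin-4-yl on a shared core

The compounds below may be only part of what the source reports. "The series", "measured", "known", "first", "only" and "open" are said of these compounds alone.

In an ADME assay on J774 cells (Mus musculus) for cytotoxicity, with a stated time of 72 h (a lower number here means that less compound is needed, a higher number that more compound is needed for the effect), compound 1 (`COc1cc2[nH]c(C)c(-c3ccccn3)c(=O)c2cc1Cl`) gives > 33300 nM as a limit of the assay. Compound 2 (`COc1cc2[nH]c(C)c(-c3cccnc3)c(=O)c2cc1Cl`) gives > 33300 nM as a limit too, so it stands without an exact number. Compound 3 (`COc1cc2[nH]c(C)c(-c3ccncc3)c(=O)c2cc1Cl`) has not yet been measured. It carries pyridin-4-yl in place of pyridin-3-yl on an aromatic carbon and has the same atoms as compound 2, joined differently. Within the data shown here, one measured step bears on this change: a step that the two limits leave unreadable from compound 1 to compound 2 is also a swap among pyridinyl groups, and its size cannot be read. All the evidence amounts to the limit of > 33300 nM in this assay, at which 2 of the 2 values shown sit, and so no step beyond the scatter is expected in this assay and no direction can be given. The expected change is a step that the limit leaves unreadable from compound 2 to compound 3 as an estimate only. For compound 3 the estimated value is 40000 nM with a range from 15000 nM to 100000 nM and a report as a limit alone is the likeliest outcome.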

Compound 3, half-maximal effective concentration: > 33300 nM
Compound 3 was reported as a limit; the forecaster's own chance of this, stated with the estimate: 80%; the middle value is on the limit's open side.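

Among these compounds, compound 3, like compound 1 and compound 2, is reported only as a limit in this assay, so no step among the three compounds can be read. What the compounds shown leave open is how far any of them lies from that limit, and whether the pyridinyl swaps change the effective concentration at all.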